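This account rests on a few compounds, and the source may have more. Where it says the series, first, only, none or still open, it means among the compounds named here.

Compound 2 `c1ccc(/C(=N/Nc2nc3ccccc3o2)C2CC2)nc1` stands at the high end of the three numbers measured in a functional assay on HeLa cells (Homo sapiens) for antiproliferative activity, read by sulforhodamine B assay; on this read-out lower numbers stand for stronger inhibition and higher numbers for weaker inhibition: compound 2 gives 4490 nM, compound 3 `C/C(=N\Nc1nc2ccccc2o1)c1ccc(C)nn1` gives 3390 nM, a value within the scatter of it, and compound 1 `CC/C(=N\Nc1nc2ccccc2o1)c1ccccn1` gives 52 nM, far lower. Compound 4 `CCC/C(=N\Nc1nc2ccccc2o1)c1ccccn1` differs from compound 2 in one place: propyl in place of cyclopropyl on a carbon with a double bond to nitrogen. For the measured compounds named here, the one measured step that bears on this is an 86-fold higher number from compound 1 to compound 2 (1.94 log units; beyond the scatter), where the three-membered ring entered and the number rose sharply. Going the other way, with the ring leaving for a propyl chain, a large fall is expected because an 86-fold higher number from compound 1 to compound 2 (1.94 log units; beyond the scatter) was so large, though compound 4 carries propyl rather than the ethyl of compound 1, so the expected step of an 18-fold lower number from compound 2 to compound 4 (1.25 log units; beyond the scatter) stops short of a full return. Compound 4 is estimated at 250 nM, within 70 nM to 1200 nM.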

Compound 4, half-maximal inhibitory concentration: 153 nM
For compound 4 the middle estimate is 1.6-fold (0.21 log units) above the measured one, and the stated range covers the measured number.
By their numbers in this assay, from the lowest: compound 1; then compound 4; then compounds 3 and 2 (each within the scatter of the next).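

Swapping cyclopropyl for propyl keeps the same 3 carbons yet gives a 29-fold lower number from compound 2 to compound 4 (1.47 log units; beyond the scatter) and so ties the weak number of compound 2 to the ring rather than to the carbon count. Lengthening the open chain from ethyl to propyl matters much less, with a 2.9-fold higher number from compound 1 to compound 4 (0.47 log units; beyond the scatter) showing a real but smaller loss. Nothing measured here explains either change.

On these data alone, whether a longer chain such as butyl continues this gentle rise remains open. So does how a branched isopropyl group or an amine would behave at this place.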